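Piperidine substituent swap on the aminopyridine amide series

This account rests on a few compounds, and the source may have more. Where it says the series, first, only, none or still open, it means among the compounds named here.

Measured compounds and their numbers in a functional assay on CHO-K1 cells for antagonist activity at transient receptor potential cation channel subfamily V member 1 (Homo sapiens), read by FLIPR; a lower number here means a stronger inhibitor, a higher number a weaker inhibitor:
- compound 1 `Cc1ccc(Nc2nc(C(F)(F)F)ccc2CNC(=O)C(C)c2ccc(NS(C)(=O)=O)c(F)c2)cc1C`: 39.3 nM
- compound 2 `CC(C(=O)NCc1ccc(C(F)(F)F)nc1N1CCCC1)c1ccc(NS(C)(=O)=O)c(F)c1`: 0.6 nM
- compound 3 `CC(C(=O)NCc1ccc(C(F)(F)F)nc1N1CCC(Cc2cc(F)cc(F)c2)CC1)c1ccc(NS(C)(=O)=O)c(F)c1`: 0.4 nM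

Compound 3 has the lowest number of the three. Its nearest neighbour is compound 2, and the two lie within the scatter of each other, so nothing can be said about an order between them. Compound 1 sits far above both.

The next compound, compound 4 `CC(C)OC1CCN(c2nc(C(F)(F)F)ccc2CNC(=O)C(C)c2ccc(NS(C)(=O)=O)c(F)c2)CC1`, keeps the whole of compound 3 apart from one group: isopropoxy in place of 3,5-difluorobenzyl on a saturated ring carbon.

Going by the values given here, only one measured step exists, a 66-fold lower number from compound 1 to compound 2 (1.82 log units; beyond the scatter), and it concerns the group on the aromatic carbon of the core, not the saturated ring carbon changed here. It shows that a cyclic amine at that position gives a much lower number than the anilino group, but it says nothing about what a substituent on that amine does. What bears more directly on the present step is the pair compound 2 and compound 3: an unsubstituted pyrrolidine and a benzyl-substituted piperidine give numbers within the scatter of each other, which suggests the group on the saturated ring carries little weight in this assay.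

Compound 4 is therefore expected to stay close to compound 3, with the step of a 1.5-fold higher number from compound 3 to compound 4 (0.18 log units; within the scatter) not beyond the scatter. The estimate for compound 4 is 0.6 nM, in the range 0.2 nM to 2.5 nM.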

Compound 4, inhibition constant: 3 nM
Estimate against measurement, compound 4: 5.0-fold (0.70 log units) below, and the stated range ends below it.
By their numbers in this assay, from the lowest: compounds 3 and 2 (each within the scatter of the next); then compound 4; then compound 1.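

In this assay, the group on the saturated ring carbon does carry weight: isopropoxy in place of 3,5-difluorobenzyl gives a 7.5-fold higher number from compound 3 to compound 4 (0.88 log units; beyond the scatter), the only step shown at this position, so the pair of compound 2 and compound 3 gave a misleading picture of it. A cyclic amine on the core does not by itself settle the number, since 4-isopropoxypiperidin-1-yl in place of pyrrolidin-1-yl gives a 5.0-fold higher number from compound 2 to compound 4 (0.70 log units; beyond the scatter), while in place of (3,4-dimethylphenyl)amino it still gives a 13-fold lower number from compound 1 to compound 4 (1.12 log units; beyond the scatter), a smaller drop than a 66-fold lower number from compound 1 to compound 2 (1.82 log units; beyond the scatter). Nothing on hand accounts for the rise with isopropoxy.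

The step changes several things at once, as isopropoxy brings no ring, 4 heavy atoms against 9, and 1 hydrogen-bond acceptor against 0, and the compounds shown cannot tell which of these goes with the higher number. An unsubstituted benzyl, a benzyloxy group, or a plain piperidin-1-yl with no group on that carbon would help to separate these.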